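Amide in place of isobutyl on the ring nitrogen

The source may hold more compounds than are shown below. What is called first, only, known or untested is meant among the compounds shown, and "the series" means these compounds.

Measured compounds:
compound 1 `O=C1NCCc2nc(C#Cc3ccccc3)sc21` gives > 10000 nM in an assay on HEK293 cells for negative allosteric modulation of metabotropic glutamate receptor 5 (Homo sapiens), read by FLIPR, with a stated time of 1 h; on this read-out lower numbers stand for stronger inhibition and higher numbers for weaker inhibition
compound 2 `CC(C)CN1CCc2nc(C#Cc3ccccc3)sc2C1` gives 650 nM in this assay
compound 3 `Fc1cccc(C#Cc2nc3c(s2)CN(C2CCOC2)CC3)c1` gives 400 nM in this assay

The value of compound 1 is a limit of the assay, not a number; it is the limit of > 10000 nM in this assay, at which 1 of the 3 values shown sits. Among the two numbers shown, compound 2 stands highest, and its nearest neighbour is compound 3, whose number sits within the scatter of repeated measurements, so no order between the two can be read.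

Compound 4 `O=C(C1CCCO1)N1CCc2nc(C#Cc3ccccc3)sc2C1` has not yet been measured. It differs from compound 2 in one place: (oxolan-2-yl)carbonyl in place of isobutyl on an amine nitrogen in a ring. No step between measured compounds of this kind is shown, so the size of the step can only be expected.

Compound 4 is expected to give a weaker result than compound 2, because compound 1 also carries a carbonyl and gives > 10000 nM as a limit, while neither compound 2 nor compound 3 holds one. The expected step is a 4.6-fold higher number from compound 2 to compound 4 (0.66 log units; beyond the scatter). For compound 4 the estimate is 3000 nM, in a range from 800 nM to 10000 nM.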

Compound 4, half-maximal inhibitory concentration: > 10000 nM
Compound 4: no number, only a limit (the forecaster's own chance of this, stated with the estimate: 30%); middle value at least 3.3-fold (0.52 log units) away from the limit.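

On the amine nitrogen in the ring, (oxolan-2-yl)carbonyl in place of isobutyl turns that nitrogen into an amide, and in this assay this change gives an at least 15-fold higher number from compound 2 to compound 4 (1.18 log units; beyond the scatter). Among these compounds, this is the first step at this position that can be read, and it shows that activity here depends strongly on the group the nitrogen carries. Compound 4 gives > 10000 nM, which is a limit of the assay and not a number, so the true size of the step stays unknown: the limit of > 10000 nM in this assay, at which 2 of the 4 values shown sit.

The change brings in a carbonyl and a five-membered ring together, so the compounds shown cannot tell which of the two matters. A plain acetyl group on the same nitrogen, or an oxolan-2-ylmethyl group, which keeps the ring without the carbonyl, would pull the two apart.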